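The source may report more compounds than this note shows. Statements on the series, on what has been measured and on what is new or still open speak of the compounds shown alone.

Measured so far in an ADME assay on microsomes (Homo sapiens) for metabolic stability (a higher number here means faster removal of the compound, a lower number slower removal), of the series
- compound 1 `CNC(=O)[C@@H]1CCCN1S(=O)(=O)c1cccc(COc2cccc3c(C(F)(F)F)cc(C)nc23)c1` gives 50 mL/min/kg
- compound 2 `CNC(=O)[C@@H]1CCCN1S(=O)(=O)c1ccc(Cl)c(COc2cccc3c(-c4cncn4C)cc(C)nc23)c1Cl` gives 33.3 mL/min/kg

The two values lie within the scatter of each other, so compound 2 stands level with compound 1 on these numbers. Compound 3 `CNC(=O)[C@@H]1CCCN1S(=O)(=O)c1ccc(Cl)c(COc2cccc3c(-c4ccncc4)cc(C)nc23)c1Cl` carries one change from compound 2, with pyridin-4-yl in place of 1-methyl-1H-imidazol-5-yl on an aromatic carbon. Among the compounds with values here, no measured pair shows this exchange, so the data give no direction for it, and no shift beyond the scatter is expected in this assay. The expected change is a 1.1-fold higher number from compound 2 to compound 3 (0.02 log units; within the scatter), which stays within the scatter. Compound 3 is estimated at 35 mL/min/kg (18 mL/min/kg to 65 mL/min/kg).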

Compound 3, clearance: 217 mL/min/kg
Estimate against measurement, compound 3: 6.2-fold (0.79 log units) below; the whole stated range lies below it.
By their numbers in this assay, from the lowest: compounds 2 and 1 (each within the scatter of the next); then compound 3.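

In this assay, the aromatic carbon opposite the ring nitrogen proves sensitive to the group it carries: pyridin-4-yl in place of 1-methyl-1H-imidazol-5-yl brings a 6.5-fold higher number from compound 2 to compound 3 (0.81 log units; beyond the scatter), although both groups have the same heavy-atom count and no net charge. Within the data shown here, this single pair is the only exchange at this position that can be read. No available evidence accounts for the step. The compounds shown leave open whether the step belongs to pyridin-4-yl itself or to the loss of 1-methyl-1H-imidazol-5-yl, a question that pyridin-3-yl or phenyl on this carbon would address.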